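A few compounds are considered here, and "the series" means these few. Any claim that something is new, unique, unknown or untested is made for them only; others in the source may bear on it.

Measured so far in an ADME assay on microsomes from liver (Rattus norvegicus) for metabolic stability, with a stated time of 60 min, tested at 1 uM; on this read-out lower numbers stand for a less stable compound and higher numbers for a more stable compound:
- compound 1 `COc1cc(-c2cnn3cc(OC)c(C(C)C)nc23)ccn1`: 14%
- compound 2 `COc1cc(-c2cnn3cc(OC)c(-c4cc(C)no4)nc23)ccn1`: 62%
- compound 3 `COc1cc(-c2cnn3cc(OC)c(C4CCOC4)nc23)ccn1`: 34%

Compound 3 holds the middle place among these three compounds. The data show a number 20 percentage points higher from compound 1 to compound 3 (beyond the scatter) and a number 28 percentage points lower from compound 2 to compound 3 (beyond the scatter).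

Compound 4 `COc1cc(-c2cnn3cc(OC)c([C@@H]4COC(C)(C)C4)nc23)ccn1` keeps the shared core and differs from compound 3 in one group, on an aromatic carbon of a six-membered aromatic ring with 2 nitrogen: a group of 7 heavy atoms (6 carbon, 1 oxygen; one five-membered non-aromatic ring with 1 hetero atom) in place of a group of 5 heavy atoms (4 carbon, 1 oxygen; one five-membered non-aromatic ring with 1 hetero atom), on an aromatic carbon. Both the leaving and the entering group contain one five-membered non-aromatic ring with 1 hetero atom.

For the measured compounds named here, no measured step makes this exact change. The nearest evidence is a number 20 percentage points higher from compound 1 to compound 3 (beyond the scatter), where oxolan-3-yl replaces isopropyl, and a number 28 percentage points lower from compound 2 to compound 3 (beyond the scatter), where it replaces 3-methyl-1,2-oxazol-5-yl. These steps show that the read-out responds to changes at this carbon, but neither gives a direction for a change to a group that keeps the ring. The largest step at this carbon is a number 48 percentage points higher from compound 1 to compound 2 (beyond the scatter), so the range is kept wide.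

In this assay the expected step is a number 3 percentage points higher from compound 3 to compound 4 (within the scatter), which means no change beyond the scatter is anticipated. Compound 4 is estimated at 37%, with an expected range from 17% to 58%.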

Compound 4, percent of the compound remaining: 30%
The estimate for compound 4 lay 7 percentage points above the measured number, and the stated range covers the measured number.
By their numbers in this assay, from the lowest: compound 1; then compounds 4 and 3 (each within the scatter of the next); then compound 2.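

In this assay, the group of 7 heavy atoms keeps the five-membered non-aromatic ring of oxolan-3-yl and gives a number 4 percentage points lower from compound 3 to compound 4 (within the scatter) on this carbon, so growing this ring from 5 to 7 heavy atoms does not move the read-out beyond the scatter. The other two comparisons place the new group where oxolan-3-yl stands, with a number 16 percentage points higher from compound 1 to compound 4 (beyond the scatter) against isopropyl and a number 32 percentage points lower from compound 2 to compound 4 (beyond the scatter) against 3-methyl-1,2-oxazol-5-yl, so among these compounds the two carrying this non-aromatic ring lie together, above compound 1 and below compound 2. Nothing measured here accounts for why the read-out holds on this change or why compound 2 stands apart.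

The compounds shown leave open whether the opposite arrangement at the defined stereocentre of compound 4 would read the same, since only one arrangement appears among them. They also leave open whether a phenyl ring, a simple amine or a carboxylic acid on this aromatic carbon would land near compound 2 or near compound 3 and compound 4 in this read-out.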